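Chloro to fluoro exchanges and growth inhibition: working notes

The source may hold more compounds than are shown below. What is called first, only, known or untested is meant among the compounds shown, and "the series" means these compounds.

Measured in a functional assay on ACHN cells (Homo sapiens); a lower number here means a stronger inhibitor of growth, a higher number a weaker inhibitor of growth:
compound 1 `O=S(=O)(/C=C/c1ccc(Cl)cc1Cl)Cc1ccc(Nc2ncnc3ccccc23)cc1`: 100 nM
compound 2 `O=S(=O)(/C=C/c1ccc(F)cc1Cl)Cc1ccc(Nc2ncnc3ccccc23)cc1`: 73000 nM
compound 3 `O=S(=O)(/C=C/c1ccc(F)cc1Cl)Cc1ccc(Nc2ncnc3cc(Cl)ccc23)cc1`: 17000 nM

Compound 1 and compound 2 differ in one place: fluoro in place of chloro on an aromatic carbon. This exchange gives a 730-fold higher number from compound 1 to compound 2 (2.86 log units; beyond the scatter). Compound 3 carries a further change against compound 1 in the core; the difference between the two cores is not broken down here. Against compound 2, compound 3 has chloro in place of hydrogen on an aromatic carbon, giving a 4.3-fold lower number from compound 2 to compound 3 (0.63 log units; beyond the scatter). Compound 3 therefore stands second highest of the three numbers in this assay, still far above compound 1.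

Compound 4 `O=S(=O)(/C=C/c1ccc(F)cc1F)Cc1ccc(Nc2ncnc3cc(Cl)ccc23)cc1` is not yet measured. It differs from compound 3 in one place: fluoro in place of chloro on an aromatic carbon. This is the same kind of change as that from compound 1 to compound 2, but not the same: there the place was meta to a chloro group and para to a large group, here it is ortho to a large group and meta to a fluoro group. For the measured compounds named here, only one measured instance of this kind of change exists, and at a different place, so it indicates direction more than size. For compound 4 the expected step is a 4.7-fold higher number from compound 3 to compound 4 (0.67 log units; beyond the scatter), resting on a 730-fold higher number from compound 1 to compound 2 (2.86 log units; beyond the scatter) as the sole shown instance. In this assay compound 4 is estimated at 80000 nM, expected between 15000 nM and 400000 nM.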

Compound 4, concentration for 50% growth inhibition: > 100000 nM
Compound 4: only a limit was reported; the forecaster's own chance of this, stated with the estimate: 35%; at least 1.2-fold (0.09 log units) between middle value and limit.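

Compound 4 is reported in this assay only as a limit of the assay and not as a number: the limit of > 100000 nM in this assay, at which 1 of the 4 values shown sits. Fluoro in place of chloro, here 2-chloro-4-fluorophenyl to 2,4-difluorophenyl, gives an at least 5.8-fold higher number from compound 3 to compound 4 (0.76 log units; beyond the scatter), so the number goes up on this core as it did on the core of compound 1, although the change sits at a different place on the ring. This shows that the direction of the change held in both instances, but it does not show that the size carries from one core to the other, and two instances at different places give no general rule for the series: the same change on two cores in this assay, a 730-fold higher number (2.86 log units; beyond the scatter) from compound 1 to compound 2 and an at least 5.8-fold higher number (0.76 log units; beyond the scatter) from compound 3 to compound 4; the limit leaves it open whether they differ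

The compounds shown leave open how the aryl group of compound 1 would read on the core of compound 3, which would show whether its low number survives the added chloro on the core. Also open, as far as these compounds go, is how the series would respond at the same place on the ring to a group other than a halogen, such as a methoxy group, an amine or a carboxylic acid.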